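A few compounds are considered here, and "the series" means these few. Any claim that something is new, unique, unknown or untested is made for them only; others in the source may bear on it.

In an ADME assay on Sf9 cells for inhibition of Amine oxidase [flavin-containing] A (Homo sapiens), read by luminescence, with stated times of 15 min and 60 min, tested at 30 uM (a lower number here means less inhibition, a higher number more inhibition at the concentration tested (going by the name of the read-out)), compound 2, with structure `CC(=O)NC[C@H]1CN(c2ccc(-c3ccc(/C=N/N4CCNCC4)cc3)c(F)c2)C(=O)O1`, gives 84%, which stands highest of the two measured numbers; compound 1, with structure `CC(=O)NC[C@H]1CN(c2ccc(-c3ccc(/C=N/N4CCSCC4)cc3)c(F)c2)C(=O)O1`, gives 81%, and the step of a number 3 percentage points higher from compound 1 to compound 2 (within the scatter). Compound 3, with structure `CC(=O)NC[C@H]1CN(c2ccc(-c3ccc(/C=N/N4CC[S+]([O-])CC4)cc3)c(F)c2)C(=O)O1`, differs from compound 2 by a group of 7 heavy atoms (4 carbon, 1 nitrogen, 1 oxygen, 1 sulfur; one six-membered non-aromatic ring with 2 hetero atoms) in place of a group of 6 heavy atoms (4 carbon, 2 nitrogen; one six-membered non-aromatic ring with 2 hetero atoms), on a double-bonded nitrogen. Going by the values given here, only the step from compound 1 to compound 2 bears on this change, and it exchanged one six-membered ring with 2 hetero atoms for another on the same double-bonded nitrogen without moving the number beyond the scatter. A similar outcome is expected here, so the estimated step is a number 2 percentage points lower from compound 2 to compound 3 (within the scatter), none beyond the scatter. Compound 3 is therefore estimated at 82%, with a range from 70% to 92%.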

Compound 3, a percentage reported as inhibition, at one concentration (the size of the read-out at that concentration, not a potency): 88%
Estimate against measurement, compound 3: 6 percentage points below; low and high end bracket the measured number.
By their numbers in this assay, from the lowest: compounds 1, 2 and 3 (each within the scatter of the next).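

With a third ring on the double-bonded nitrogen, this one holding both sulfur and oxygen and having 0 hydrogen-bond donors, this assay shows a number 4 percentage points higher from compound 2 to compound 3 (within the scatter) and a number 7 percentage points higher from compound 1 to compound 3 (within the scatter). All three six-membered rings at this position therefore give numbers that cannot be told apart, including when the ring's hydrogen-bond donor is absent. Going by these compounds, whether an open-chain amine or a carboxylic acid on this nitrogen would give a number beyond the scatter remains open. Nothing available offers an explanation for these numbers.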